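Hydrazone aryl variation at the cytotoxicity limit

The source may hold more compounds than are shown below. What is called first, only, known or untested is meant among the compounds shown, and "the series" means these compounds.

Compound 1 `CN(C)CCn1cnnc1-c1cc(Oc2ccc(NC(=O)N/N=C/c3c[nH]c4ccccc34)cc2F)ccn1` in a functional assay on A549 cells (Homo sapiens) for cytotoxicity, read by MTT assay, with a stated time of 72 h (on this read-out higher numbers stand for weaker inhibition and lower numbers for stronger inhibition), gives 820 nM. Compound 2 `COc1cc(/C=N/NC(=O)Nc2ccc(Oc3ccnc(-c4nncn4CCN(C)C)c3)c(F)c2)cc(OC)c1OC` reaches only the limit of this assay, > 100000 nM. Compound 3 `CN(C)CCn1cnnc1-c1cc(Oc2ccc(NC(=O)N/N=C/c3cccc(O)c3)cc2F)ccn1` likewise reaches only the limit of this assay, > 100000 nM. Both of these are reported as limits, not as numbers, so compound 3 stands at the weak end of the three values, with no number of its own; its position is summed up by the limit of > 100000 nM in this assay, at which 2 of the 3 values shown sit.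

The measured steps are an at least 120-fold higher number from compound 1 to compound 2 (2.08 log units; beyond the scatter) and an at least 120-fold higher number from compound 1 to compound 3 (2.08 log units; beyond the scatter), both large, while a step that the two limits leave unreadable from compound 2 to compound 3 because both ends are limits. None of these steps covers the change from compound 3 to compound 4 `Cc1cc(/C=N/NC(=O)Nc2ccc(Oc3ccnc(-c4nncn4CCN(C)C)c3)c(F)c2)cc(C)c1O`, which is 4-hydroxy-3,5-dimethylphenyl in place of 3-hydroxyphenyl on a carbon with a double bond to nitrogen. Among the compounds with values here, the two aryl variants measured so far, compound 2 and compound 3, both sit at the limit, and the only compound with a readable number, compound 1, carries the indolyl group that compound 4 also lacks.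

Compound 4 is therefore expected to sit at or near the limit again, with a number no higher from compound 3 to compound 4 (the limit leaves the size open) as the expected step. The estimate for compound 4 in this assay is 100000 nM, expected to fall between 20000 nM and 300000 nM.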

Compound 4, half-maximal inhibitory concentration: 1640 nM
Beside the measured number, compound 4's estimate is 61-fold (1.79 log units) above it; measured number below the stated range.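

In this assay, a readable number at this position does not depend on the 1H-indol-3-yl group: placing 4-hydroxy-3,5-dimethylphenyl on the carbon with a double bond to nitrogen gives an at least 60-fold lower number from compound 3 to compound 4 (1.78 log units; beyond the scatter), and replacing 3,4,5-trimethoxyphenyl with it gives an at least 60-fold lower number from compound 2 to compound 4 (1.78 log units; beyond the scatter). Set against the indolyl group, the same change gives a 2.0-fold higher number from compound 1 to compound 4 (0.30 log units; within the scatter), so this read-out does not separate compound 1 from compound 4. The phenyl series is therefore not uniformly at the limit, and the values of compound 2 and compound 3 remain limits, not numbers: the limit of > 100000 nM in this assay, at which 2 of the 4 values shown sit.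

Compound 3 and compound 4 differ both in where the hydroxyl sits and in the methyl groups, so the change does not show which of these matters; a 4-hydroxyphenyl or a 3,5-dimethylphenyl group on the same carbon would separate the two. As far as these compounds go, the step from compound 2 to compound 3 cannot be read, and it remains open whether an amine, as in 4-aminophenyl, can stand in place of the hydroxyl and keep a readable number.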